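The source may hold more compounds than are shown below. What is called first, only, known or untested is meant among the compounds shown, and "the series" means these compounds.

In an assay on HEK293 cells for displacement of a labelled ligand from Melanocortin receptor 4 (Homo sapiens) (on this read-out higher numbers stand for weaker inhibition and lower numbers for stronger inhibition), compound 1 `Cc1ccc(N2CCN(C(=O)[C@@H]3CN(C4CCOCC4)C[C@H]3c3ccc(Cl)cc3)CC2)c([C@@H](NC(=O)[C@@H](C)N)C(C)C)c1` gives 7.3 nM, the second highest of the three numbers measured. Compound 2 `CC(C)[C@H](NC(=O)CCN(C)C)c1cccc(F)c1N1CCN(C(=O)[C@@H]2CN(C(C)C)C[C@H]2c2ccc(Cl)cc2)CC1` gives 5.3 nM, within the scatter of compound 1, while compound 3 `CC(C)[C@H](NC(=O)CCN(C)C)c1cccc(F)c1N1CCN(C(=O)[C@@H]2CN(C(C)C)C[C@H]2c2cc(F)ccc2F)CC1` gives 2050 nM, well beyond it. For the measured compounds named here, the only measured step, a 390-fold higher number from compound 2 to compound 3 (2.59 log units; beyond the scatter), replaces the 4-chlorophenyl on a saturated ring carbon and does not touch the position altered here. Compound 4 `Cc1ccc(N2CCN(C(=O)[C@@H]3CN(C4CCOCC4)C[C@H]3c3ccc(Cl)cc3)CC2)c([C@@H](NC(=O)CN)C(C)C)c1` differs from compound 1 by hydrogen in place of methyl on a saturated chain carbon bound to an amine nitrogen and a carbonyl carbon. Going by the values given here, no measured step bears on this change, so the data give no ground for a shift in this assay beyond the scatter. Compound 4 is therefore expected to give 10 nM, between 4 nM and 30 nM. The expected step is a 1.4-fold higher number from compound 1 to compound 4 (0.14 log units; within the scatter), a movement within the scatter.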

Compound 4, inhibition constant: 2 nM
The estimate for compound 4 lay 5.0-fold (0.70 log units) above the measured number; measured number below the stated range.
By their numbers in this assay, from the lowest: compound 4; then compounds 2 and 1 (each within the scatter of the next); then compound 3.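

Taking the methyl off the 1-aminoethyl group to leave aminomethyl gives a 3.7-fold lower number from compound 1 to compound 4 (0.56 log units; beyond the scatter) in this assay. The earlier compounds shown here said nothing about this position, and this step shows that the number responds to a change on this saturated chain carbon bound to an amine nitrogen and a carbonyl carbon, and that the methyl is not required for a low number. Nothing measured here explains the shift.

From the compounds shown here alone, it remains open whether an ethyl or a hydroxymethyl group on this carbon would raise or lower the number. Also open, going by these compounds, is whether aminomethyl keeps its effect with 2,5-difluorophenyl in place of 4-chlorophenyl.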